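Changing the amide's aryl group in a flavonol series

The source may report more compounds than this note shows. Statements on the series, on what has been measured and on what is new or still open speak of the compounds shown alone.

Three compounds share one core and differ only in the aryl group attached to the carbonyl carbon of an amide. Compound 1 `O=C(Nc1cccc(-c2oc3cc(-c4ccc(F)cc4)ccc3c(=O)c2O)c1)c1ccc(Cl)cc1` carries a 4-chlorophenyl there; in a functional assay on HeLa cells (Homo sapiens) for antiproliferative activity, read by CCK-8 assay, with a stated time of 72 h (on this read-out higher numbers stand for weaker inhibition and lower numbers for stronger inhibition), compound 1 gives 3670 nM. Compound 2 `Cc1ccccc1C(=O)Nc1cccc(-c2oc3cc(-c4ccc(F)cc4)ccc3c(=O)c2O)c1` carries a 2-methylphenyl and in this assay compound 2 gives 11900 nM. Compound 3 `O=C(Nc1cccc(-c2oc3cc(-c4ccc(F)cc4)ccc3c(=O)c2O)c1)c1ccc(Br)cc1` carries a 4-bromophenyl and in this assay compound 3 gives 9740 nM. Compound 1 thus has the lowest number of the three, with a 2.7-fold higher number from compound 1 to compound 3 (0.42 log units; beyond the scatter) and a 3.2-fold higher number from compound 1 to compound 2 (0.51 log units; beyond the scatter), while compound 2 and compound 3 differ by a 1.2-fold lower number from compound 2 to compound 3 (0.09 log units; within the scatter).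

Compound 4 `COc1ccc(C(=O)Nc2cccc(-c3oc4cc(-c5ccc(F)cc5)ccc4c(=O)c3O)c2)c(F)c1` is not yet measured. Relative to compound 1 the change is 2-fluoro-4-methoxyphenyl in place of 4-chlorophenyl on a carbonyl carbon. The two steps that bear on it both leave from compound 1 and both exchange the 4-chlorophenyl for a different aryl group: one gave a 3.2-fold higher number from compound 1 to compound 2 (0.51 log units; beyond the scatter), the other 2.7-fold higher number from compound 1 to compound 3 (0.42 log units; beyond the scatter). On that basis a modest rise in number is expected for compound 4, estimated as a 2.5-fold higher number from compound 1 to compound 4 (0.39 log units; beyond the scatter). In this assay compound 4 is therefore expected to give about 9000 nM, with a plausible range from 3000 nM to 27000 nM.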

Compound 4, half-maximal inhibitory concentration: 16100 nM
For compound 4 the middle estimate is 1.8-fold (0.25 log units) below the measured one; low and high end bracket the measured number.
By their numbers in this assay, from the lowest: compound 1; then compounds 3, 2 and 4 (each within the scatter of the next).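

In this assay, a third replacement of the 4-chlorophenyl on the amide carbonyl also gives a higher number: the 2-fluoro-4-methoxyphenyl brings a 4.4-fold higher number from compound 1 to compound 4 (0.64 log units; beyond the scatter), and unlike the groups before it, this one contains a hydrogen-bond acceptor. Compound 4 cannot be told apart from the other two replacements, with a 1.7-fold higher number from compound 3 to compound 4 (0.22 log units; within the scatter) and a 1.4-fold higher number from compound 2 to compound 4 (0.13 log units; within the scatter), so compounds 2, 3 and 4 form a single cluster despite their different aryl groups, while compound 1, whose steps to all three lie beyond the scatter, remains the most potent of the four. Nothing available explains why the 4-chlorophenyl stands apart from the other three groups.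

On these data alone, the entering group differs from the 4-chlorophenyl in two substituents at once, so the separate contributions of the fluoro and the methoxy remain unknown, and a phenyl ring carrying only one of them would be needed to divide the step. Also open, as far as these compounds go, is how an unsubstituted phenyl, a saturated cyclohexyl or a ring bearing an amine or a carboxylic acid would behave at this carbonyl carbon.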